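A few compounds are considered here, and "the series" means these few. Any claim that something is new, unique, unknown or untested is made for them only; others in the source may bear on it.

Of the compounds shown here, three sharing one core have been tested in a toxicity assay on NIH3T3 cells (Mus musculus) for cytotoxicity, read by resazurin assay; on this read-out lower numbers stand for an effect already at smaller amounts and higher numbers for an effect only at larger amounts of compound. In this assay compound 3 `O=C(OC1CCCCC1)c1ccc(NCc2cncn2Cc2ccc(-c3ccccc3)cc2)cc1-c1ccccc1` gives > 10000 nM, which is a limit and not a number. Compound 1 `Clc1ccc(NCc2cncn2Cc2ccc(-c3ccccc3)cc2)cc1-c1ccccc1` gives > 1000 nM, also a limit. Compound 2 `O=C(c1ccc(NCc2cncn2Cc2ccc(-c3ccccc3)cc2)cc1-c1ccccc1)N1CCCCC1` gives > 1000 nM, again a limit. Compound 3 therefore has no exact place on the scale, and neither do its two relatives.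

The next compound, compound 4 `CCCC(=O)c1ccc(NCc2cncn2Cc2ccc(-c3ccccc3)cc2)cc1-c1ccccc1`, keeps the core and carries propyl in place of cyclohexyloxy on a carbonyl carbon.

The measured step closest to this change swaps a group on the same carbonyl carbon, and it reads a step that the two limits leave unreadable from compound 2 to compound 3. The other two steps replace chloro on an aromatic carbon, and they read a step that the two limits leave unreadable from compound 1 to compound 2 and a step that the two limits leave unreadable from compound 1 to compound 3. None of the three supplies a size to carry over. No step beyond the usual scatter can therefore be predicted in this assay, and no direction can be favoured. The estimated change is an at least 2.0-fold lower number from compound 3 to compound 4 (0.30 log units; that floor lies within the scatter), and it is a weak guess that may well end in another limit. For compound 4 the expected value is 5000 nM, with an estimated range from 1500 nM to 20000 nM.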

Compound 4, half-maximal effective concentration: > 10000 nM
Compound 4: a limit, no number; the forecaster's own chance of this, stated with the estimate: 80%; middle value at least 2.0-fold (0.30 log units) away from the limit.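

Compound 4 also gives only a limit, so its steps from compound 1, compound 2 and compound 3 cannot be read in this assay. The compounds shown leave open where any of the four would give an exact number in this assay, and whether swapping the groups on the carbonyl carbon changes that number at all.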